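The source may hold more compounds than are shown below. What is called first, only, known or untested is meant among the compounds shown, and "the series" means these compounds.

Within the data shown here, compound 2 `COc1ccccc1CNc1nc(Nc2ccc(N3CCN(C)CC3)cn2)ncc1Cl` gives 10800 nM in a functional assay on Jurkat cells (Homo sapiens) for inhibition, read by CCK-8 assay, with a stated time of 48 h (a higher number here means a weaker inhibitor of growth, a lower number a stronger inhibitor of growth), and holds the only actual number measured here. Compound 1 `CN1CCN(c2ccc(Nc3ncc(Cl)c(NCc4ccc(F)cc4)n3)nc2)CC1` gives only a limit, > 100000 nM, in this assay. The step of an at least 9.2-fold lower number from compound 1 to compound 2 (0.96 log units; beyond the scatter) therefore rests on that limit (the limit of > 100000 nM in this assay, at which 1 of the 2 values shown sits). Compound 3 `CC(C)c1ccccc1Nc1nc(Nc2ccc(N3CCN(C)CC3)cn2)ncc1Cl` differs from compound 2 by 2-isopropylphenyl in place of 2-methoxybenzyl on a nitrogen on an aromatic ring. Among the measured compounds shown here, the single measured step exchanged one ring on the same arm while keeping its chain carbon, so it bears only loosely on this change, and the data hold nothing on losing that carbon. No shift beyond the scatter is expected, a step of a 1.1-fold lower number from compound 2 to compound 3 (0.03 log units; within the scatter). Compound 3 is estimated at 10000 nM, within 1500 nM to 70000 nM.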

Compound 3, concentration for 50% growth inhibition: 5140 nM
For compound 3 the middle estimate is 1.9-fold (0.29 log units) above the measured one; the range from low to high includes it.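

In this assay, the change to 2-isopropylphenyl on the nitrogen gives a 2.1-fold lower number from compound 2 to compound 3 (0.32 log units; beyond the scatter) and shows that an arm without the chain carbon can still inhibit growth, modestly better than 2-methoxybenzyl. The wider step an at least 19-fold lower number from compound 1 to compound 3 (1.28 log units; beyond the scatter) is only a bound, since compound 1 gives a limit and not a number: the limit of > 100000 nM in this assay, at which 1 of the 3 values shown sits.

Two things changed at once, the chain carbon and the ring substituent, so their shares stay unseparated. A 2-methoxyphenyl or a 2-isopropylbenzyl on the same nitrogen would tell them apart.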